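The compounds below may be only part of what the source reports. "The series", "measured", "known", "first", "only" and "open" are said of these compounds alone.

In a functional assay on MIA PaCa-2 cells (Homo sapiens) for antiproliferative activity, read by sulforhodamine B assay, with a stated time of 48 h (a lower number here means a stronger inhibitor, a higher number a weaker inhibitor), compound 1 (`COc1cc(OC)c2sc(-c3ccc(N/C=C\C(=O)c4cc(OC)c(OC)c([N+](=O)[O-])c4)c(C)c3)nc2c1`) gives 10400 nM and compound 2 (`COc1cc(OC)c2sc(-c3ccc(N/C=C\C(=O)c4cc(OC)c(OC)c(OC)c4)cc3)nc2c1`) gives 26800 nM, so compound 2 holds the higher of the two numbers, by more than the usual scatter. Compound 3 (`COc1cc(OC)c2sc(-c3ccc(N/C=C\C(=O)c4cc(OC)c(OC)c([N+](=O)[O-])c4)cc3)nc2c1`) is compound 2 with nitro in place of methoxy on an aromatic carbon. Within the data shown here, no measured pair shows this swap alone. Compound 3 shares its nitro with compound 1, which gives 10400 nM, so a moderately lower number is expected in this assay. The estimated change is a 1.8-fold lower number from compound 2 to compound 3 (0.25 log units; within the scatter). The expected value for compound 3 is 15000 nM, within an estimated range of 6000 nM to 35000 nM.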

Compound 3, half-maximal inhibitory concentration: 12700 nM
Beside the measured number, compound 3's estimate is 1.2-fold (0.07 log units) above it; the measured number falls inside the stated range.
By their numbers in this assay, from the lowest: compounds 1 and 3 (each within the scatter of the next); then compound 2.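

In this assay, nitro in place of methoxy on this aromatic carbon can now be read alone, and the step of a 2.1-fold lower number from compound 2 to compound 3 (0.32 log units; beyond the scatter) is modest but beyond the scatter. Hydrogen in place of methyl can also be read alone, and the step of a 1.2-fold higher number from compound 1 to compound 3 (0.09 log units; within the scatter) stays within the scatter, so this pair shows no readable effect of the methyl. No measurement here accounts for the nitro step.

As far as these compounds go, whether an amine or a carboxylic acid at this place would give a lower or higher number stays open. So does whether the nitro step would be the same with the methyl present.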